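The source may hold more compounds than are shown below. What is called first, only, known or untested is meant among the compounds shown, and "the series" means these compounds.

Measured compounds, read in an ADME assay on RBL-2H3 cells (Rattus norvegicus) for cytotoxicity, read by CCK-8 assay, with a stated time of 24 h; on this read-out higher numbers stand for lower toxicity in this test and lower numbers for higher toxicity in this test:
- compound 1 `COc1cc(NC(=O)c2ccc(C)c(C#Cc3cc(-c4cnn(C)c4)cnc3N)c2)cc(OC)c1` gives 397 nM
- compound 2 `Cc1ccc(C(=O)Nc2ccc(OC(F)(F)F)cc2)cc1C#Cc1cc(-c2cnn(C)c2)cnc1N` gives 41 nM

Going by the values given here, compound 2 carries the lowest of the two numbers in this assay, and its only neighbour is compound 1, separated from it by the step of a 9.7-fold lower number from compound 1 to compound 2 (0.99 log units; beyond the scatter), which arose from a 4-(trifluoromethoxy)phenyl in place of a 3,5-dimethoxyphenyl on the amide-type nitrogen.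

Compound 3 `Cc1ccc(C(=O)Nc2ccc(Cl)c(C(F)(F)F)c2)cc1C#Cc1cc(-c2cnn(C)c2)cnc1N` is not yet measured. Its change from compound 2 is 4-chloro-3-(trifluoromethyl)phenyl in place of 4-(trifluoromethoxy)phenyl on an amide-type nitrogen. Among the compounds with values here, no measured step involves the entering group; the single step from compound 1 to compound 2 only shows that exchanging the aryl group on the amide-type nitrogen can move this assay by a modest amount. A step of similar or smaller size is therefore expected, most plausibly towards a lower number, estimated as a 1.4-fold lower number from compound 2 to compound 3 (0.14 log units; within the scatter). For compound 3 the expected value is 30 nM, with a range from 10 nM to 120 nM.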

Compound 3, half-maximal cytotoxic concentration: 21 nM
Compound 3: the middle estimate sits 1.4-fold (0.15 log units) above what was measured; measured number inside the range.
By their numbers in this assay, from the lowest: compounds 3 and 2 (each within the scatter of the next); then compound 1.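

In this assay the exchange on the amide-type nitrogen gives a 2.0-fold lower number from compound 2 to compound 3 (0.29 log units; within the scatter) and so does not separate 4-chloro-3-(trifluoromethyl)phenyl from 4-(trifluoromethoxy)phenyl, which shows that the low numbers at this position do not depend on the oxygen of the trifluoromethoxy group. Set against 3,5-dimethoxyphenyl, the entering group gives a 19-fold lower number from compound 1 to compound 3 (1.28 log units; beyond the scatter) as a large step, so compound 2 and compound 3 both stand apart from compound 1 on this read-out. No measurement offered here explains either step.

From the compounds shown here alone, whether an aryl group on the amide-type nitrogen is needed for these low numbers remains open. Also open, going by these compounds, is how this assay would read with a basic amine such as a piperazine or with a carboxylic acid on that aryl ring.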